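The compounds below may be only part of what the source reports. "The series", "measured", "known", "first", "only" and "open" are said of these compounds alone.

Within the data shown here, in a functional assay on L1210 cells (Mus musculus), read by MTT assay (a lower number here means a stronger inhibitor, a higher number a weaker inhibitor), compound 1 `CC[C@@]1(O)[C@@H](CO)O[C@@H](n2ccc(N)nc2=O)[C@@H]1O` gives 269000 nM, the only plain number among the measured compounds. Compound 2 `C#C[C@]1(O)[C@@H](CO)O[C@@H](n2ccc(=O)[nH]c2=O)[C@@H]1O` is recorded there with several entries, > 350000 nM; 130 nM (2 entries), which do not agree with one another. Compound 3 `Nc1ccn([C@@H]2O[C@H](CO)[C@](O)(C3CC3)[C@H]2O)c(=O)n1` differs from compound 1 by cyclopropyl in place of ethyl on a saturated ring carbon. No step between measured compounds is shown, so the data offer no measured size for such a change. The step of a 1.1-fold higher number from compound 1 to compound 3 (0.05 log units; within the scatter) is expected to stay within the usual scatter. Compound 3 is accordingly estimated at 300000 nM, with a range from 100000 nM to 1000000 nM.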

Compound 3, half-maximal inhibitory concentration: > 350000 nM
Compound 3 was reported as a limit; the forecaster's own chance of this, stated with the estimate: 40%; middle value at least 1.1-fold (0.06 log units) away from the limit.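

In this assay, among these compounds, the change from ethyl to cyclopropyl on this saturated ring carbon gives the first step at this position: an at least 1.3-fold higher number from compound 1 to compound 3 (0.11 log units; that floor lies within the scatter). Compound 3 is recorded only as a limit: the limit of > 350000 nM in this assay, at which 1 of the 3 values shown sits. The step therefore has a floor but no full size, and that floor lies within the scatter, so the data do not separate the two groups here.

As far as these compounds go, whether an amine or a longer chain on this carbon would move the number clear of the scatter stays open. Compound 2 offers no firm reference point either: the several entries of compound 2 in this assay, > 350000 nM; 130 nM (2 entries)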